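Chloro on Compound 2: A Modest Rise Expected

A few compounds are considered here, and "the series" means these few. Any claim that something is new, unique, unknown or untested is made for them only; others in the source may bear on it.

Going by the values given here, in a functional assay on HCT-116 cells (Homo sapiens) for antiproliferative activity, read by MTT assay, with a stated time of 72 h (a higher number here means a weaker inhibitor, a lower number a stronger inhibitor), compound 2 (`COc1cc(CCc2ccccc2)cc(OC)c1O`) gives 530 nM as the lowest of the three numbers so far, with compound 3 (`COc1cc(CCc2ccc(F)cc2)cc(OC)c1O`) at 1190 nM in the middle and compound 1 (`COc1cc(CCc2ccncc2)cc(OC)c1O`) at 3740 nM at the top. Compound 4 (`COc1cc(CCc2ccccc2Cl)cc(OC)c1O`) is still unmeasured, and chloro in place of hydrogen on an aromatic carbon sets out its difference from compound 2: chloro in place of hydrogen on an aromatic carbon, ortho to a large group. The other measured step, a 7.1-fold lower number from compound 1 to compound 2 (0.85 log units; beyond the scatter) for phenyl in place of pyridin-4-yl, is a different kind of change and bears on this one only weakly. Among the compounds with values here, no measured compound carries a group at the place of the chloro. Taking a 2.2-fold higher number from compound 2 to compound 3 (0.35 log units; beyond the scatter) as the only halogen guide, for fluoro in place of hydrogen on an aromatic carbon, a modest rise in the number is expected here as well. The expected change is a 1.7-fold higher number from compound 2 to compound 4 (0.23 log units; within the scatter) in size, and its direction remains less than certain. Compound 4 is estimated at 900 nM as a middle value, with an expected range of 350 nM to 2500 nM for the measurement.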

Compound 4, half-maximal inhibitory concentration: 250 nM
Estimate against measurement, compound 4: 3.6-fold (0.56 log units) above; the measured number lies below the stated range.
By their numbers in this assay, from the lowest: compound 4; then compound 2; then compound 3; then compound 1.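

In this assay, chloro in place of hydrogen on an aromatic carbon, ortho to a large group, gives a 2.1-fold lower number from compound 2 to compound 4 (0.33 log units; beyond the scatter), so this place on the ring accepts a group and the number falls. Compound 4 thus holds the lowest number of the four, and its step is opposite in direction to that for fluoro in place of hydrogen on an aromatic carbon, which gave a 2.2-fold higher number from compound 2 to compound 3 (0.35 log units; beyond the scatter), so halogen on this ring does not push the number one way in every case. No measurement shown explains the difference between these two steps.

The compounds shown leave open whether the fall belongs to chloro or to its place, as no compound shown has fluoro where compound 4 has chloro. They also leave open whether a methyl group or an amine at this place would lower the number too.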